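Series notes: cyano in place of trifluoromethoxy, compound 4

The compounds below may be only part of what the source reports. "The series", "measured", "known", "first", "only" and "open" are said of these compounds alone.

Three compounds sharing the core of compound 1 `O=C(Nc1ccc(OC(F)(F)F)cc1)c1cc(F)ccc1O` have been measured in a functional assay on HL-60 cells (Homo sapiens) for cytotoxicity, read by luminescence and CellTiter-Glo, with a stated time of 3 days; a lower number here means a stronger inhibitor, a higher number a weaker inhibitor. Compound 1 gives 850 nM, the highest of the three numbers recorded. Compound 2 `O=C(Nc1cc(Cl)cc(Cl)c1)c1cc(F)ccc1O` gives 600 nM, and compound 3 `O=C(Nc1ccc(OC(F)(F)F)c(Cl)c1)c1cc(F)ccc1O` gives 550 nM; both lie within the scatter of the value for compound 1, so no order among the three can be read from these numbers. For the measured compounds named here, the single recorded step between compounds differing in one place, a 1.5-fold lower number from compound 1 to compound 3 (0.19 log units; within the scatter), puts chloro in place of hydrogen on an aromatic carbon and stays within the scatter.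

Compound 4 `N#Cc1ccc(NC(=O)c2cc(F)ccc2O)cc1` differs from compound 1 by cyano in place of trifluoromethoxy on an aromatic carbon. Going by the values given here, no measured pair exchanges trifluoromethoxy for cyano, so no recorded step bears directly on this change. Among the compounds with values here, the only step available, a 1.5-fold lower number from compound 1 to compound 3 (0.19 log units; within the scatter), concerns a different group and was itself within the scatter, and the three measured numbers sit in a narrow band despite their differing substituents. The expected step of a 1.1-fold higher number from compound 1 to compound 4 (0.02 log units; within the scatter) is therefore one that should not pass beyond the scatter in either direction. The estimate for compound 4 in this assay is 900 nM, with a range from 400 nM to 2000 nM.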

Compound 4, half-maximal inhibitory concentration: 1420 nM
Beside the measured number, compound 4's estimate is 1.6-fold (0.20 log units) below it; the measured number falls inside the stated range.
By their numbers in this assay, from the lowest: compounds 3, 2, 1 and 4 (each within the scatter of the next, the first and the last beyond it).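

Working notes on the position para to a large group: in this assay this is the first direct reading of a change there, a 1.7-fold higher number from compound 1 to compound 4 (0.22 log units; within the scatter), with cyano in place of trifluoromethoxy. The exchange of a group of 5 heavy atoms for one of 2 heavy atoms therefore stays inside the scatter, so no order can be read between this pair, and these two groups are not separated by this assay. Nothing measured at hand speaks to what lies behind the number for compound 4.

Still open, on these data alone, is whether a group of another kind at this position, such as an amine or a carboxylic acid, would carry the number beyond the scatter, as the two groups compared here do not. Also open, as far as these compounds go, is whether chloro in place of hydrogen on an aromatic carbon, the change that gave compound 3 from compound 1, would give a step of similar size when cyano rather than trifluoromethoxy occupies this position.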